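The source may hold more compounds than are shown below. What is called first, only, known or untested is meant among the compounds shown, and "the series" means these compounds.

Of the compounds shown here, two have been measured so far. Compound 1, `Cc1ccccc1Nc1nc(Nc2ccc(N3CCN(C(=O)OC(C)(C)C)CC3)cc2)ncc1Cl`, gives 3260 nM in a functional assay on MDA-MB-231 cells (Homo sapiens) for inhibition, read by CCK-8 assay, with a stated time of 48 h; a higher number here means a weaker inhibitor of growth, a lower number a stronger inhibitor of growth. Compound 2, `Cc1ccc(CNc2nc(Nc3ccc(N4CCN(C)CC4)cn3)ncc2Cl)cc1`, gives 18600 nM in this assay, which is the higher of the two numbers, so compound 2 is the weaker growth inhibitor of the pair, and the gap to compound 1 lies beyond the usual scatter.

The next compound, compound 3, `CN1CCN(c2ccc(Nc3ncc(Cl)c(Nc4ccc(C(C)(C)C)cc4)n3)nc2)CC1`, has not yet been tested. It differs from compound 2 in one place: 4-(tert-butyl)phenyl in place of 4-methylbenzyl on a nitrogen on an aromatic ring. The rest of the molecule, including the shared core and the side bearing the methylpiperazine, is unchanged.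

Within the data shown here, no pair of measured compounds differs in only this place, so there is no directly comparable step to lean on. Among the measured compounds shown here, the only guide is that compound 2 stands at the weak end of what has been seen, while compound 1 reaches 3260 nM. On that basis a moderate gain in potency is expected, with the step of a 2.7-fold lower number from compound 2 to compound 3 (0.42 log units; beyond the scatter) likely larger than the scatter but not dramatic. For compound 3 the expected value in this assay is 7000 nM, within a range from 2500 nM to 20000 nM.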

Compound 3, concentration for 50% growth inhibition: 16200 nM
Compound 3: the middle estimate sits 2.3-fold (0.36 log units) below what was measured, within the range that was stated.
By their numbers in this assay, from the lowest: compound 1; then compounds 3 and 2 (each within the scatter of the next).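

In this assay, putting 4-(tert-butyl)phenyl in place of 4-methylbenzyl on a nitrogen on an aromatic ring gives a 1.1-fold lower number from compound 2 to compound 3 (0.06 log units; within the scatter), so the two compounds cannot be told apart in this read-out. Among these compounds, this is the first comparison in the set where only one place differs, and it shows that these two all-carbon groups, each carrying one six-membered aromatic ring, are interchangeable at this position as far as this measurement can tell, even though they differ in size and in how the ring is attached to the nitrogen. No independent measurement is available to explain why the two groups give matching results.

From the compounds shown here alone, both groups tested here contain only carbon and hydrogen, so it remains open whether a group carrying an amine or a carboxylic acid on the ring would give a different result at this position. Going by these compounds, it is also open whether a group with a longer chain between the nitrogen and the ring, or a plain methyl with no ring at all, would separate from these two compounds beyond the scatter.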